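Swapping 2-chlorophenyl for 4-fluorophenyl in compound 3

The compounds below may be only part of what the source reports. "The series", "measured", "known", "first", "only" and "open" are said of these compounds alone.

Three related compounds have been tested in a functional assay on SGC-7901 cells (Homo sapiens) for antiproliferative activity, read by MTT assay, with a stated time of 24 h; a higher number here means a weaker inhibitor, a lower number a stronger inhibitor. Compound 1 `Cc1cccc(NNC(=O)c2ccc(NS(=O)(=O)c3cnc(O)nc3O)cc2)c1` gives > 20000 nM, which is a limit of the assay and not a number. Compound 2 `O=C(NNc1cccc(Cl)c1)c1ccc(NS(=O)(=O)c2cnc(O)nc2O)cc1` gives 11600 nM. Among the measured compounds shown here, compound 3 `O=C(NNc1ccccc1Cl)c1cccc(NS(=O)(=O)c2cnc(O)nc2O)c1` gives 2270 nM, the lowest number so far and lower than that of compound 2 by more than the usual scatter.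

Compound 4 `O=C(NNc1ccc(F)cc1)c1cccc(NS(=O)(=O)c2cnc(O)nc2O)c1` has not yet been measured. Its difference from compound 3 is 4-fluorophenyl in place of 2-chlorophenyl on an amine nitrogen.

For the measured compounds named here, only one single-place step has been measured, an at least 1.7-fold lower number from compound 1 to compound 2 (0.23 log units; that floor lies within the scatter), and it offers weak guidance. It is a different change, its floor lies within the scatter, and it rests on a limit: the limit of > 20000 nM in this assay, at which 1 of the 3 values shown sits. Going by the values given here, no measured step therefore shows what this exchange does. Among the compounds with values here, compound 3 at 2270 nM is the best number in this assay so far, so a modest move towards higher numbers seems more likely than a further fall. The expected change is a 2.0-fold higher number from compound 3 to compound 4 (0.30 log units; within the scatter). For compound 4 the estimate is 4500 nM, with an expected range from 1400 nM to 15000 nM.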

Compound 4, half-maximal inhibitory concentration: > 20000 nM
Compound 4 was reported as a limit; the forecaster's own chance of this, stated with the estimate: 12%; at least 4.4-fold (0.64 log units) between middle value and limit.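

In this assay, among the compounds shown here, placing 4-fluorophenyl in place of 2-chlorophenyl on the amine nitrogen gives an at least 8.8-fold higher number from compound 3 to compound 4 (0.94 log units; beyond the scatter), the first single-place step here that lies beyond the usual scatter. It shows that the aryl group at this position is not freely interchangeable, at least for these two groups, and that this exchange loses much of the activity seen in the better compound of the pair. Compound 4 gives > 20000 nM, which is a limit of the assay and not a number, so the step gives only a minimum size and the real gap could be larger, with the assay's ceiling now hiding the true values of two compounds: the limit of > 20000 nM in this assay, at which 2 of the 4 values shown sit.

This exchange changes both the halogen and its place on the phenyl ring, and the compounds shown cannot say which of the two matters, or whether both do. A 4-chlorophenyl or a 2-fluorophenyl group on the same amine nitrogen would pull these two changes apart, and an unsubstituted phenyl group would show what either halogen contributes.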